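Methoxy-to-Hydrogen Step in a Series Measured for Cytotoxicity

The source may report more compounds than this note shows. Statements on the series, on what has been measured and on what is new or still open speak of the compounds shown alone.

Measured so far in a functional assay on NCI-H460 cells (Homo sapiens) for cytotoxicity, read by sulforhodamine B assay, with a stated time of 48 h, tested at 0.01 uM; a higher number here means a weaker effect of the compound at the concentration tested, a lower number a stronger effect:

compound 1 `COc1cc(-c2cc(/C=C/C(=O)c3ccc(N)cc3)[nH]n2)cc(OC)c1OC`, giving 102%
compound 2 `COc1ccc(-c2cc(/C=C/C(=O)c3ccc(N)cc3)[nH]n2)cc1OC`, giving 101%
compound 3 `COc1cc(C(=O)/C=C/c2cc(-c3cc(OC)c(OC)c(OC)c3)n[nH]2)cc(OC)c1OC`, giving 102%

All three numbers lie close together at the top of the set, and none of the compounds shows a measurable effect at the concentration tested. Compound 2 differs from compound 1 by hydrogen in place of methoxy on an aromatic carbon; in this assay the step is a number 1 percentage points lower from compound 1 to compound 2 (within the scatter), so the removal of the methoxy group leaves the read-out unchanged here. Compound 3 stands level with compound 1 at the digits given, and the difference between the core of compound 3 and the core of compound 1 is not broken down here.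

Compound 4 `COc1ccc(-c2cc(/C=C/C(=O)c3cc(OC)c(OC)c(OC)c3)[nH]n2)cc1OC` is the unmeasured member. It differs from compound 3 by hydrogen in place of methoxy on an aromatic carbon, and the place described around the change is word for word the same as for the change from compound 1 to compound 2, so it is the same change made on the core of compound 3. Because a number 1 percentage points lower from compound 1 to compound 2 (within the scatter), the step from compound 3 to compound 4 is expected to be flat as well, estimated as a number 1 percentage points lower from compound 3 to compound 4 (within the scatter). Compound 4 is therefore expected to give about 101% in this assay, with the estimate spanning 92% to 110%. The whole expectation rests on a single measured pair, compounds 1 and 2, and on the shared inactivity of compounds 1, 2 and 3.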

Compound 4, a percentage reported as activity, at one concentration (the size of the read-out at that concentration, not a potency): 100%
Compound 4: the middle estimate sits 1 percentage points above what was measured; measured number inside the range.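

In this assay the new step is a number 2 percentage points lower from compound 3 to compound 4 (within the scatter), and it can be set directly beside the earlier step on the other core: the same change on two cores in this assay, a number 1 percentage points lower (within the scatter) from compound 1 to compound 2 and a number 2 percentage points lower (within the scatter) from compound 3 to compound 4, 1 percentage points apart, within the scatter of two such steps

Replacing methoxy with hydrogen on an aromatic carbon therefore leaves the read-out flat on both the core of compound 1 and the core of compound 3, and on this evidence the change carries from one core to the other without a visible difference. That agreement is only a shared absence of effect at a single concentration, with all four compounds level at the top of the set, so it does not show that the change would carry over in the same way in a compound with a measurable effect, and two cores are a narrow basis for any wider rule.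

The compounds shown leave open whether a hydroxyl group, a chlorine atom or a longer alkoxy chain such as ethoxy in place of the methoxy would move the read-out away from this level. They also leave open whether the two steps would still agree at a concentration where these compounds give a measurable effect.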